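A few compounds are considered here, and "the series" means these few. Any claim that something is new, unique, unknown or untested is made for them only; others in the source may bear on it.

In an ADME assay on Huh-7 cells (Homo sapiens) for cytotoxicity, with a stated time of 72 h (on this read-out higher numbers stand for lower toxicity in this test and lower numbers for higher toxicity in this test), compound 3 `CCC(C)n1nc(-c2cccs2)c(O)c(C2=NS(=O)(=O)c3cc(NS(C)(=O)=O)ccc3N2)c1=O` gives only a limit, > 33000 nM, and no number. Compound 1 `CS(=O)(=O)Nc1ccc2c(c1)S(=O)(=O)N=C(c1c(O)c(-c3cccs3)nn(CCC3CC3)c1=O)N2`, which carries 2-cyclopropylethyl, also gives only a limit, > 33000 nM. Compound 2 `CCCC(C)n1nc(-c2cccs2)c(O)c(C2=NS(=O)(=O)c3cc(NS(C)(=O)=O)ccc3N2)c1=O`, which carries 1-methylbutyl, is likewise a limit, > 33000 nM. The whole series therefore comes down to the limit of > 33000 nM in this assay, at which 3 of the 3 values shown sit.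

Compound 4 `CS(=O)(=O)Nc1ccc2c(c1)S(=O)(=O)N=C(c1c(O)c(-c3cccs3)nn(CCC3CCCC3)c1=O)N2` departs from compound 3 by one change: 2-cyclopentylethyl in place of sec-butyl on an aromatic nitrogen.

For the measured compounds named here, three measured steps bear on this change, all at the same nitrogen or its chain: a step that the two limits leave unreadable from compound 1 to compound 3, a step that the two limits leave unreadable from compound 1 to compound 2 and a step that the two limits leave unreadable from compound 2 to compound 3. None of them has a readable size, so they give neither a magnitude nor a direction. The closest guide is compound 1, whose ring-bearing ethyl chain comes with the limit > 33000 nM. No step beyond the usual scatter is therefore expected in this assay, in either direction.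

The expected change is a number no higher from compound 3 to compound 4 (the limit leaves the size open).

Compound 4 is estimated at 33000 nM, with an expected range from 14000 nM to 60000 nM, and it may well be reported as a limit again.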

Compound 4, half-maximal cytotoxic concentration: > 1000 nM
Compound 4: only a limit was reported (the forecaster's own chance of this, stated with the estimate: 80%); the middle value lies beyond the limit too.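

In this assay compound 4 gives only a limit, > 1000 nM, so its steps to compound 1, compound 2 and compound 3 cannot be read. The compounds shown leave open whether changing the group on the aromatic nitrogen shifts the half-maximal cytotoxic concentration at all, in either direction.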